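Phenoxy in place of benzyl: notes on compound 4

This account rests on a few compounds, and the source may have more. Where it says the series, first, only, none or still open, it means among the compounds named here.

Measured so far in a functional assay on the whole organism with Mus musculus as the target, in the maximal electroshock model; on this read-out lower numbers stand for an effect already at smaller amounts and higher numbers for an effect only at larger amounts of compound:

compound 1 `CNC(=O)[C@@H](CO)NCc1ccc(OCc2ccccc2)cc1` gives 22.8 mg/kg
compound 2 `C[C@@H](NCc1ccc(Cc2ccccc2)cc1)C(N)=O` gives 22.5 mg/kg
compound 3 `C[C@@H](NCc1ccc(CCc2ccccc2)cc1)C(N)=O` gives 17.8 mg/kg

In this assay compound 3 gives 17.8 mg/kg and stands within the scatter of both compound 1 and compound 2, so the three values do not separate.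

Compound 4 `C[C@@H](NCc1ccc(COc2ccccc2)cc1)C(N)=O` is the next to be read. It carries phenoxy in place of benzyl on a saturated chain carbon bound to an aromatic carbon, and the counted difference from compound 3 is phenoxy in place of benzyl on a saturated chain carbon bound to an aromatic carbon.

Within the data shown here, no measured step covers this exact exchange. The closest evidence is a 1.3-fold lower number from compound 2 to compound 3 (0.10 log units; within the scatter) with benzyl in place of phenyl at the same kind of place. That single step stays within the scatter, and it is a different exchange, so it bears on the new one only loosely. Compound 1 differs from compound 3 in more than one place, and its value says only that it lies within the scatter of compound 3. The data give no direction for the exchange, so no shift beyond the scatter is expected in this assay. The expected change is a 1.1-fold higher number from compound 3 to compound 4 (0.03 log units; within the scatter) and this remains an estimate resting on very few values.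

For compound 4 the estimated value is 19 mg/kg with an expected range from 9 mg/kg to 40 mg/kg in this assay.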

Compound 4, dose for half-maximal effect: 10.6 mg/kg
The estimate for compound 4 lay 1.8-fold (0.25 log units) above the measured number, within the range that was stated.
By their numbers in this assay, from the lowest: compounds 4, 3, 2 and 1 (each within the scatter of the next, the first and the last beyond it).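

In this assay, phenoxy in place of benzyl on a saturated chain carbon bound to an aromatic carbon gives a 1.7-fold lower number from compound 3 to compound 4 (0.23 log units; within the scatter), so this exchange does not separate the two compounds, and the oxygen counted as the one added hydrogen-bond acceptor comes with no shift beyond the scatter. Phenoxy in place of phenyl at the same kind of place gives a 2.1-fold lower number from compound 2 to compound 4 (0.33 log units; beyond the scatter), the only single-place step shown that passes the scatter, and only modestly, whereas a 1.3-fold lower number from compound 2 to compound 3 (0.10 log units; within the scatter) stays within it. This position therefore tolerates all three groups in this read-out, with a first modest separation between the phenyl and phenoxy compounds, and no measurement at hand offers an explanation for that separation.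

Every group shown at this position ends in an unsubstituted phenyl ring, so it remains open how a longer chain such as phenylpropyl, or an anilino group in place of phenoxy, would read here. Also open, going by these compounds, is whether the step from phenyl to phenoxy would carry over to the core of compound 1, which differs from compound 4 in more than one place.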